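The compounds below may be only part of what the source reports. "The series", "measured", "known", "first", "only" and "open" are said of these compounds alone.

In a functional assay on MDA-MB-435 cells (Homo sapiens) for cytotoxicity, read by MTT assay, with a stated time of 72 h (a higher number here means a weaker inhibitor, a lower number a stronger inhibitor), three compounds have numbers so far:
compound 1 `COc1cccc(CNC(=O)c2nc(Br)c3cccnc3c2N[C@H]2CC[C@H](N)CC2)c1` gives 7000 nM;
compound 2 `N[C@H]1CC[C@H](Nc2c(C(=O)NCc3ccc(Cl)cc3Cl)nc(Br)c3cccnc23)CC1` gives 5800 nM;
compound 3 `N[C@H]1CC[C@H](Nc2c(C(=O)NCc3cccs3)nc(Br)c3cccnc23)CC1` gives 4100 nM.

Compound 3 stands at the low end of these three numbers, though every gap to it lies within the scatter: a 1.4-fold lower number from compound 2 to compound 3 (0.15 log units; within the scatter) and a 1.7-fold lower number from compound 1 to compound 3 (0.23 log units; within the scatter). Compound 4 `C[C@H](NC(=O)c1nc(Br)c2cccnc2c1N[C@H]1CC[C@H](N)CC1)c1ccc(F)cc1` differs from compound 3 in one place: 1-(4-fluorophenyl)ethyl in place of (thiophen-2-yl)methyl on an amide-type nitrogen. All three measured steps swap the group on this same nitrogen, and each stayed within the scatter, including a 1.2-fold lower number from compound 1 to compound 2 (0.08 log units; within the scatter). Within the data shown here, no measured step covers the entering group itself, so nothing here points to a shift beyond the scatter. The expected step is a 1.2-fold higher number from compound 3 to compound 4 (0.09 log units; within the scatter). In this assay compound 4 is estimated at 5000 nM, with a range from 2000 nM to 12000 nM.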

Compound 4, half-maximal inhibitory concentration: > 10000 nM
Compound 4: a limit, no number; the forecaster's own chance of this, stated with the estimate: 5%; middle value at least 2.0-fold (0.30 log units) away from the limit.
By their numbers in this assay, from the lowest: compounds 3, 2 and 1 (each within the scatter of the next). At a limit, above all of these: compound 4.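

In this assay compound 4 gives > 10000 nM, a limit and not a number. Among these compounds, the change on the amide-type nitrogen gives an at least 2.4-fold higher number from compound 3 to compound 4 (0.38 log units; beyond the scatter), the first step at this position beyond the scatter, while the floors of an at least 1.7-fold higher number from compound 2 to compound 4 (0.23 log units; that floor lies within the scatter) and an at least 1.4-fold higher number from compound 1 to compound 4 (0.15 log units; that floor lies within the scatter) stay within it. So this position does respond to its group, but how far remains unknown, and the reading rests on a limit: the limit of > 10000 nM in this assay, at which 1 of the 4 values shown sits.

Open, as far as these compounds go, is whether the 4-fluorophenyl ring or the extra methyl on the chain carbon matters more, which a 4-fluorobenzyl group would separate. Also open, from the compounds shown here alone, is how this nitrogen behaves with a chain ending in an amine, such as 2-aminoethyl.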